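The compounds below may be only part of what the source reports. "The series", "measured", "known", "first", "only" and "open" are said of these compounds alone.

Compound 1 `CO[C@H]1CC[C@@H](CNc2cc(NCc3cnccc3C(F)(F)F)ncc2C#N)CC1` gives 70 nM in an assay on isolated protein for inhibition of protein kinase C theta type (Homo sapiens), read by TR-FRET, with a stated time of 2 h; on this read-out higher numbers stand for weaker inhibition and lower numbers for stronger inhibition. Compound 2 `CC1(C)C[C@@H](Nc2cc(NCc3cnccc3C(F)(F)F)ncc2C#N)CC[C@H]1O` gives 120 nM in this assay.

Within the data shown here, compound 2 stands within the scatter of compound 1, the only other number, the step being a 1.7-fold higher number from compound 1 to compound 2 (0.23 log units; within the scatter). Compound 3 `CC1(C)[C@@H](C(N)=O)C[C@H]1Nc1cc(NCc2cnccc2C(F)(F)F)ncc1C#N` differs from compound 2 by 3-carbamoyl-2,2-dimethylcyclobutyl in place of 4-hydroxy-3,3-dimethylcyclohexyl on a nitrogen on an aromatic ring. Among the measured compounds shown here, the one measured step at this nitrogen, a 1.7-fold higher number from compound 1 to compound 2 (0.23 log units; within the scatter), exchanged the whole substituent and stayed within the scatter, so a change here has so far moved little. Compound 3 is therefore expected to land near compound 2, with a 1.3-fold higher number from compound 2 to compound 3 (0.10 log units; within the scatter) as the estimated step. The estimate for compound 3 is 150 nM, ranging from 50 nM to 450 nM.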

Compound 3, half-maximal inhibitory concentration: 1.4 nM
For compound 3 the middle estimate is 110-fold (2.03 log units) above the measured one, and the stated range ends above it.
By their numbers in this assay, from the lowest: compound 3; then compounds 1 and 2 (each within the scatter of the next).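

The substituent on this nitrogen can matter far more than the first pair suggested: in this assay there is an 86-fold lower number from compound 2 to compound 3 (1.93 log units; beyond the scatter) and a 50-fold lower number from compound 1 to compound 3 (1.70 log units; beyond the scatter), both beyond the scatter. So the small step between compounds 1 and 2 did not mean that this position tolerates any change. In compound 3, a four-membered ring carrying a carbamoyl group replaces the larger rings, with the same count of heavy atoms as in compound 2.

Ring size and the carbamoyl group change together here, so their shares stay unseparated; a cyclobutyl carrying a hydroxyl or a carboxylic acid, or a cyclohexyl carrying a carbamoyl group, would pull them apart. No measurement at hand gives a reason for the much lower number.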